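Bromo for nitro in a cyclized hydrazone series

The source may report more compounds than this note shows. Statements on the series, on what has been measured and on what is new or still open speak of the compounds shown alone.

Two open-chain hydrazones and one ring-closed analogue were tested in a functional assay on MCF7 cells (Homo sapiens) for inhibition, read by sulforhodamine B assay, with a stated time of 48 h; on this read-out lower numbers stand for stronger inhibition of growth and higher numbers for weaker inhibition of growth. Compound 1 `N#CCC(=O)N/N=C(/CBr)c1ccc(Br)cc1` gives 40600 nM. Compound 2 `N#CCC(=O)N/N=C(/CBr)c1ccc([N+](=O)[O-])cc1` gives 18400 nM. The step of a 2.2-fold higher number from compound 2 to compound 1 (0.34 log units; beyond the scatter) corresponds to bromo in place of nitro on an aromatic carbon. Compound 3 `N#CCC1=NN=C(c2ccc([N+](=O)[O-])cc2)C(CC(=O)c2ccc([N+](=O)[O-])cc2)O1` gives 1600 nM, the lowest of the three numbers; the difference between its core and the core of compound 2 is not broken down here, and the two values simply show compound 3 well ahead of compound 2 in this assay.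

Compound 4 `N#CCC1=NN=C(c2ccc([N+](=O)[O-])cc2)C(CC(=O)c2ccc(Br)cc2)O1` has not yet been measured. Its difference from compound 3 is bromo in place of nitro on an aromatic carbon, the same change already seen between compound 2 and compound 1. On that basis compound 4 is expected to sit somewhat above compound 3 in this assay, with a step of about a 2.2-fold higher number from compound 3 to compound 4 (0.34 log units; beyond the scatter), because the earlier step of a 2.2-fold higher number from compound 2 to compound 1 (0.34 log units; beyond the scatter) was modest. For the measured compounds named here, the estimate for compound 4 is therefore 3500 nM, with a likely range from 1500 nM to 8000 nM; the single precedent makes this expectation tentative.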

Compound 4, concentration for 50% growth inhibition: 36000 nM
Compound 4: middle estimate off by 10-fold (1.01 log units), on the low side, and the stated range ends below it.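

On the ring-closed core, bromo in place of nitro gives a 23-fold higher number from compound 3 to compound 4 (1.35 log units; beyond the scatter) in this assay, so in both pairs the bromo compound has the higher number. For the compounds shown here, the size of the step, however, does not carry over from one core to the other: the same change on two cores in this assay, a 2.2-fold higher number (0.34 log units; beyond the scatter) from compound 2 to compound 1 and a 23-fold higher number (1.35 log units; beyond the scatter) from compound 3 to compound 4, 10-fold (1.01 log units) apart, beyond the scatter of two such steps Two pairs show only that the core can matter to the size of this step, and they cannot say whether the gap follows the core as a whole or the particular ring that changes, as compound 3 holds two 4-nitrophenyl groups and only one of them differs in compound 4.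

The compounds shown leave open whether bromo on the remaining 4-nitrophenyl group of the ring-closed core would cost as much as the step seen here. They also leave open how chloro, a methoxy group or an amine in the place of nitro would read on either core in this assay.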